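Enantiomeric switch at the ring stereocentre of a hydroxamate

The source may hold more compounds than are shown below. What is called first, only, known or untested is meant among the compounds shown, and "the series" means these compounds.

Measured so far:
compound 1, `O=C(NO)[C@@H]1CSCN1S(=O)(=O)c1ccc2ccccc2c1`, > 50000 nM
compound 2, `O=C(NO)[C@@H]1CCC(=O)N1Cc1ccccc1Cl`, "not determined" (no result reported)
compound 3, `NC(=O)[C@@H]1CCC(=O)N1Cc1ccccc1Cl`, "not determined" (no result reported)

The read-out throughout is an assay on isolated protein for inhibition of matrix metalloproteinase-9 (Homo sapiens), read by fluorescence, with stated times of 1 h and 30 min; on this read-out lower numbers stand for stronger inhibition and higher numbers for weaker inhibition. Compound 1 sits at the limit of this assay, > 50000 nM, a limit and not a number; (the limit of > 50000 nM in this assay, at which 1 of the 3 values shown sits). For compound 2 the result is "not determined" (no result reported), and for compound 3 it is likewise "not determined" (no result reported). Compound 2 therefore stands without any number of its own: of the three entries, one is a limit and the remaining one is empty, so there is nothing against which compound 2 can be placed.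

The piece follows the change from compound 2 to compound 4, `O=C(NO)[C@H]1CCC(=O)N1Cc1ccccc1Cl`. (the two compounds have the same atoms and bonds and differ only in configuration as drawn: 1 of 1 stereo elements differ; a stereocentre at a saturated ring carbon is drawn S in compound 2 and R in compound 4). No step between measured compounds is shown, so nothing sets the size or the direction of this change in this assay in advance. Within the data shown here, with the only measured value being a limit, the expected step cannot be sized from the data, and the account here is of the estimate for compound 4 alone.

Compound 4 is expected to give 20000 nM, within 2000 nM to 100000 nM.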

Compound 4, half-maximal inhibitory concentration: > 500000 nM
Compound 4 ended at the assay's limit; the forecaster's own chance of this, stated with the estimate: 50%; middle value at least 25-fold (1.39 log units) from the limit.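

In this assay compound 4 gives > 500000 nM, which is a limit of the assay and not a number. Among these compounds, compound 2 stands at "not determined" (no result reported), so no step from it to compound 4 can be read. The compounds shown leave open how far, and in which direction, the switch from S in compound 2 to R in compound 4 moves inhibition.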